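Aryl swap on a fused core, pyrazolopyridine series

This account rests on a few compounds, and the source may have more. Where it says the series, first, only, none or still open, it means among the compounds named here.

Measured so far:
- compound 1 `CCCS(=O)(=O)Nc1ccc(F)c(C(=O)c2n[nH]c3ncc(-c4cccc(OC)c4)cc23)c1F`: 6.3%
- compound 2 `CCCS(=O)(=O)Nc1ccc(F)c(C(=O)c2n[nH]c3ncc(-c4ccc(Cl)cc4Cl)cc23)c1F`: 22%

In an assay for binding affinity to dual specificity mitogen-activated protein kinase kinase 4 (Homo sapiens), read by KINOMEscan, tested at 100 nM (on this read-out lower numbers stand for a stronger effect and higher numbers for a weaker effect at the one concentration tested), compound 2 stands highest of the two numbers shown; its nearest neighbour, compound 1, lies lower by a number 15.7 percentage points higher from compound 1 to compound 2 (beyond the scatter), a step beyond the scatter. Compound 3 `CCCS(=O)(=O)Nc1ccc(F)c(C(=O)c2n[nH]c3ncc(-c4ccc(C)c(C)c4)cc23)c1F` differs from compound 2 only at the aromatic carbon of the fused core: 3,4-dimethylphenyl in place of 2,4-dichlorophenyl on an aromatic carbon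

Among the compounds with values here, the single measured step, a number 15.7 percentage points higher from compound 1 to compound 2 (beyond the scatter), concerns a different aryl swap at the same place, so it gives only a sense of scale: exchanging one substituted phenyl for another moved the read-out by a modest amount. For compound 3 a step of similar or smaller size is therefore expected, most likely downward toward the value of compound 1, as a number 9 percentage points lower from compound 2 to compound 3 (within the scatter), though a change within the scatter cannot be ruled out. Compound 3 is thus estimated at 13%, with a range from 3% to 35%.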

Compound 3, a percentage reported as activity, at one concentration (the size of the read-out at that concentration, not a potency): 20%
For compound 3 the middle estimate is 7 percentage points below the measured one; low and high end bracket the measured number.
By their numbers in this assay, from the lowest: compound 1; then compounds 3 and 2 (each within the scatter of the next).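

In this assay, replacing 2,4-dichlorophenyl with 3,4-dimethylphenyl on the aromatic carbon of the shared core gives a number 2 percentage points lower from compound 2 to compound 3 (within the scatter), so this position does not separate these two aryl groups, although their substituents and substitution patterns differ. The 3-methoxyphenyl group nonetheless remains apart from the new aryl group, with a number 13.7 percentage points higher from compound 1 to compound 3 (beyond the scatter), which shows that the gap first seen with compound 2 is not confined to the 2,4-dichlorophenyl group. Nothing available accounts for this result.

On these data alone, it remains open whether the methoxy group itself sets compound 1 apart, or whether a plain phenyl ring would fall with compound 1 or with compound 2 and compound 3. As far as these compounds go, what an amine or a carboxylic acid on this ring would do to the read-out also stays open.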